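The source may hold more compounds than are shown below. What is called first, only, known or untested is meant among the compounds shown, and "the series" means these compounds.

Working notes on the series in an assay on HEK293 cells for agonist activity at transient receptor potential cation channel subfamily M member 8 (Homo sapiens), read by fluorescence and calcium flux, with a stated time of 15 min; a higher number here means that more compound is needed for the effect, a lower number that less compound is needed. Of the compounds shown here, three have been measured. Compound 1 `CCN(Cc1ccccn1)C(=O)COc1ccc(C)cc1` gives 16000 nM. Compound 2 `CCN(Cc1cccs1)C(=O)c1cc2cc(C)ccc2[nH]1` gives 2010 nM. Compound 3 `COCCN(Cc1cccs1)C(=O)COc1ccc(C)cc1` gives 400 nM. Among these, compound 2 stands second highest: compound 3 sits at a lower number, a gap beyond the scatter, and compound 1 at a higher number, also beyond the scatter. Among the compounds with values here, none of the three pairs differs in a single place, so no measured step is available to calibrate any change.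

Compound 4 `CCN(Cc1cccs1)C(=O)c1cc2cc(C)ccc2n1C` has not yet been measured in this assay. Relative to compound 2 the difference is methyl in place of hydrogen on an aromatic nitrogen. Within the data shown here, nothing among the measured compounds isolates this change, so the direction rests on judgement alone. The expected step from compound 2 to compound 4 is a 1.5-fold higher number from compound 2 to compound 4 (0.17 log units; within the scatter), a modest move toward a higher number that may not exceed the scatter. Compound 4 is therefore estimated at 3000 nM, with a range from 800 nM to 12000 nM.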

Compound 4, half-maximal effective concentration: "not active" (no number reported)
Compound 4: no number reported, so the estimate cannot be set against anything.
By their numbers in this assay, from the lowest: compound 3; then compound 2; then compound 1.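

In this assay, within the data shown here, compound 4 gives "not active" (no number reported), so no step from compound 2 to compound 4 can be read. Nothing available bears on this result. The compounds shown leave open how far methyl in place of hydrogen on the aromatic nitrogen moves the number.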